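From bromo to hydroxy at the assay's limit

The source may hold more compounds than are shown below. What is called first, only, known or untested is meant among the compounds shown, and "the series" means these compounds.

Compound 1 `COC(=O)c1c(-c2cc(OC)cc(OC)c2)oc2ccccc2c1=O`: 6.99 ug/mL
Compound 2 `COC(=O)c1c(-c2ccc(Br)cc2)oc2ccccc2c1=O`: > 25 ug/mL (a limit)
Compound 3 `COC(=O)c1c(-c2ccc([N+](=O)[O-])cc2)oc2ccccc2c1=O`: > 25 ug/mL (a limit)

In a functional assay on HT-29 cells (Homo sapiens) for cytotoxicity, read by MTT assay, with a stated time of 6 days (a higher number here means that more compound is needed for the effect, a lower number that less compound is needed), compound 2 gives > 25 ug/mL, which is a limit and not a number. The picture so far is the limit of > 25 ug/mL in this assay, at which 2 of the 3 values shown sit. Compound 4 `COC(=O)c1c(-c2ccc(O)cc2)oc2ccccc2c1=O` changes compound 2 by hydroxy in place of bromo on an aromatic carbon. Within the data shown here, the only measured step that also replaces the bromo group is a step that the two limits leave unreadable from compound 2 to compound 3, so it offers no size to carry over. Only a small move toward a lower number in this assay is therefore expected. The expected step is an at least 1.2-fold lower number from compound 2 to compound 4 (0.09 log units; that floor lies within the scatter). For compound 4, the estimated value is 20 ug/mL, with an expected range from 8 ug/mL to 50 ug/mL.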

Compound 4, concentration for half-maximal effect: > 25 ug/mL
Compound 4: only a limit was reported; the forecaster's own chance of this, stated with the estimate: 55%; middle value at least 1.2-fold (0.09 log units) away from the limit.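

In this assay compound 4 gives > 25 ug/mL, which is a limit, so the steps to it from compound 2 and compound 3 cannot be read. Whether bromo, nitro and hydroxy differ at all in this assay stays open, as the values gather at one point: the limit of > 25 ug/mL in this assay, at which 3 of the 4 values shown sit.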